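The compounds below may be only part of what the source reports. "The series", "measured", "known", "first", "only" and "open" are said of these compounds alone.

Measured compounds in a functional assay on KB cells (Homo sapiens) for antiproliferative activity, read by sulforhodamine B assay, with a stated time of 3 days; on this read-out lower numbers stand for an effect already at smaller amounts and higher numbers for an effect only at larger amounts of compound:
compound 1, `CCCCc1ccc(-c2cc(=O)c3c(o2)C(CC)(CC)C(=O)C(CC)=C3O)cc1`, gives 111 uM.
compound 2, `CCC1=C(O)c2c(oc(-c3ccc(C(F)(F)F)cc3)cc2=O)C(CC)(CC)C1=O`, gives 35.7 uM.
compound 3, `CCC1=C(O)c2c(oc(-c3ccc(Br)cc3)cc2=O)C(CC)(CC)C1=O`, gives only a limit of the assay, > 48.1 uM.

Where compound 3 stands: its value is a limit and not a number, so it can only be placed at or beyond the weak end of the three. The step of a 3.1-fold lower number from compound 1 to compound 2 (0.49 log units; beyond the scatter) is the only one read in full. The step of an at least 1.3-fold higher number from compound 2 to compound 3 (0.12 log units; that floor lies within the scatter) has a floor within the scatter, and the step that the limit leaves unreadable from compound 1 to compound 3 is unreadable; both rest on (the limit of > 48.1 uM in this assay, at which 1 of the 3 values shown sits).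

Compound 4 is `CCC1=C(O)c2c(oc(-c3ccccc3F)cc2=O)C(CC)(CC)C1=O`. Against compound 3 the change is 2-fluorophenyl in place of 4-bromophenyl on an aromatic carbon. For the measured compounds named here, no measured step touches a 2-fluorophenyl; the measured steps all vary the group in the other position of the phenyl ring, and they reach from the butyl of compound 1 to the trifluoromethyl of compound 2, a modest span. Nothing in them indicates that the new group should move the number far from where compound 3 sits. The expected step is a step that the limit leaves unreadable from compound 3 to compound 4, which is small and lies around the limit. Compound 4 is therefore estimated at 55 uM in this assay, with a range from 20 uM to 150 uM, and a real chance that only a limit is reported again.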

Compound 4, concentration for half-maximal effect: > 56.2 uM
Compound 4: a limit, no number (the forecaster's own chance of this, stated with the estimate: 40%); at least 1.0-fold (0.00 log units) between middle value and limit.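

Compound 3 and compound 4 both stand as limits and not as numbers in this assay, and the step between them cannot be read. The compounds shown leave open whether 2-fluorophenyl and 4-bromophenyl differ at all in this assay, and how far beyond its limit the real value of either compound lies.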